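The source may report more compounds than this note shows. Statements on the series, on what has been measured and on what is new or still open speak of the compounds shown alone.

Measured so far: compound 1 `CC1=CC[C@H](C(C)(C)N=C=S)CC1` and compound 2 `CC1=CC[C@H](C(C)(C)NC(=S)N/N=C/c2ccc(O)cc2)CC1`.

Compound 1 gives only a limit in a functional assay on PC-3 cells (Homo sapiens) for inhibition, read by sulforhodamine B assay, with a stated time of 48 h (a higher number here means a weaker inhibitor of growth, a lower number a stronger inhibitor of growth), namely > 100000 nM. In this assay compound 2 gives 53800 nM. Compound 2 thus stands as the only number shown, the other value being (the limit of > 100000 nM in this assay, at which 1 of the 2 values shown sits).

Compound 3 `CC1=CC[C@H](C(C)(C)NC(=S)N/N=C/c2ccc(Cl)cc2)CC1` differs from compound 2 by chloro in place of hydroxy on an aromatic carbon. Within the data shown here, no measured step of this kind exists here, so a modest step toward stronger growth inhibition is expected, possibly within the scatter. The expected step is a 1.8-fold lower number from compound 2 to compound 3 (0.25 log units; within the scatter). Compound 3 is estimated at 30000 nM, between 10000 nM and 90000 nM.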

Compound 3, concentration for total growth inhibition: 1700 nM
For compound 3 the middle estimate is 18-fold (1.25 log units) above the measured one, outside the stated range (below it).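

Among these compounds, replacing hydroxy with chloro on the aromatic carbon para to a large group is the first single-place change that can be read in this assay, and it gives a 32-fold lower number from compound 2 to compound 3 (1.50 log units; beyond the scatter). This shows that growth inhibition in this assay depends strongly on the group at this position. Nothing measured here accounts for the size of this step.

Going by these compounds, with a single pair, it remains open whether chloro is special at this position or whether fluoro, methoxy or an amine would give a similar value. On these data alone, whether the same change would hold at another position on the ring also remains open.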